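Compound 3 gives up its bromo and methoxy

The source may hold more compounds than are shown below. What is called first, only, known or untested is meant among the compounds shown, and "the series" means these compounds.

Measured so far in a physicochemical assay for lipophilicity; a lower number here means a more polar compound, a higher number a more lipophilic compound:
Compound 1 `COc1ccc(C2C[C@@]3(ON2c2ccccc2)C(=O)O[C@@H]2[C@H]3CC[C@H](C)[C@]3(O)C=CC(=O)[C@@]23C)cc1`: 3.25
Compound 2 `C[C@H]1CC[C@@H]2[C@@H](OC(=O)[C@]23CC(c2ccccc2)N(c2ccccc2)O3)[C@]2(C)C(=O)C=C[C@@]12O`: 3.19
Compound 3 `COc1ccc(C2C[C@@]3(ON2c2ccccc2)C(=O)O[C@@H]2[C@H]3CC[C@H](C)[C@]3(O)C=CC(=O)[C@@]23C)cc1Br`: 3.98

Of these three, compound 3 stands highest in this assay, and its gaps to the other two lie beyond the scatter. The next compound, compound 4 `C[C@H]1CC[C@@H]2[C@@H](OC(=O)[C@]23CC(c2ccccc2F)N(c2ccccc2)O3)[C@]2(C)C(=O)C=C[C@@]12O`, has not yet been measured. The change from compound 3 is 2-fluorophenyl in place of 3-bromo-4-methoxyphenyl on a saturated ring carbon.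

Among the compounds with values here, three measured steps bear on this change. Hydrogen in place of methoxy gave a number 0.06 log units lower from compound 1 to compound 2 (within the scatter). Bromo in place of hydrogen gave a number 0.73 log units higher from compound 1 to compound 3 (beyond the scatter). The full exchange of phenyl for 3-bromo-4-methoxyphenyl gave a number 0.79 log units higher from compound 2 to compound 3 (beyond the scatter). The change to compound 4 removes that same 3-bromo-4-methoxyphenyl group, so a drop of similar size is expected, and the bromo step suggests where most of it would arise. Within the data shown here, no measured compound carries a fluoro group, so the data give no step for that addition, and the phenyl of compound 2, at 3.19, serves as the nearest guide. The expected change is a number 0.68 log units lower from compound 3 to compound 4 (beyond the scatter). For compound 4 the estimated value is 3.3, with an expected range of 3 to 3.6.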

Compound 4, partition coefficient: 3.35
For compound 4 the middle estimate is 0.05 log units below the measured one, within the range that was stated.
By their numbers in this assay, from the lowest: compounds 2, 1 and 4 (each within the scatter of the next); then compound 3.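

In this assay, within the data shown here, the 2-fluorophenyl group on the saturated ring carbon next to the ring nitrogen provides the first reading for a fluoro group at this position, and fluoro in place of hydrogen gives a number 0.16 log units higher from compound 2 to compound 4 (within the scatter). Among these compounds, exchanging 4-methoxyphenyl for 2-fluorophenyl likewise gives a number 0.10 log units higher from compound 1 to compound 4 (within the scatter), whereas exchanging 3-bromo-4-methoxyphenyl for the same group gives a number 0.63 log units lower from compound 3 to compound 4 (beyond the scatter), so among the four compounds only compound 3, the sole bromo compound, stands apart, and none goes against this. Nothing measured here accounts for these differences.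

The compounds shown leave open whether a 2-bromophenyl or 2-chlorophenyl group at this place would read with compound 4 or with compound 3, and so whether the gap set by compound 3 follows the halogen itself, its place on the phenyl ring, or the methoxy group that accompanies it. They also leave open how a phenyl ring carrying an amine or a carboxylic acid would read in this assay at this same position on the shared core.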